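Adding a second methyl to compound 2: working notes

The compounds below may be only part of what the source reports. "The series", "measured", "known", "first", "only" and "open" are said of these compounds alone.

- compound 1 `Cc1cc2nc(-c3cn(-c4ccccc4)nc3-c3ccccc3)[nH]c2cc1C` gives 14500 nM
- compound 2 `Cc1ccc2[nH]c(-c3cn(-c4ccccc4)nc3-c3ccc(F)cc3)nc2c1` gives 1440 nM

In a functional assay on A549 cells (Homo sapiens) for antiproliferative activity, read by MTT assay, with a stated time of 48 h (a lower number here means a stronger inhibitor, a higher number a weaker inhibitor), compound 2 holds the lower of the two numbers with 1440 nM and compound 1 lies higher with 14500 nM by a gap beyond the scatter. Compound 3 `Cc1cc2nc(-c3cn(-c4ccccc4)nc3-c3ccc(F)cc3)[nH]c2cc1C` differs from compound 2 by methyl in place of hydrogen on an aromatic carbon and in nothing else. For the measured compounds named here, no measured pair shows this change alone, and compound 1 differs from compound 2 in more than one place. Compound 1 also carries this methyl and stands at 14500 nM so the expectation tilts slightly upward. The expected step of a 1.5-fold higher number from compound 2 to compound 3 (0.18 log units; within the scatter) is a small rise in the number, probably within the scatter. For compound 3 the estimated value in this assay is 2200 nM with an expected range of 700 nM to 7000 nM for now.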

Compound 3, half-maximal inhibitory concentration: > 50000 nM
Compound 3 was reported as a limit; the forecaster's own chance of this, stated with the estimate: 3%; middle value at least 22-fold (1.35 log units) from the limit.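

In this assay, methyl in place of hydrogen on an aromatic carbon, ortho to a methyl group, gives an at least 34-fold higher number from compound 2 to compound 3 (1.54 log units; beyond the scatter), so in the fluoro-bearing pair this single added carbon separates a measurable compound from one at the top of the range. With both methyl groups present, adding fluoro gives an at least 3.4-fold higher number from compound 1 to compound 3 (0.53 log units; beyond the scatter), so the fluoro that accompanies the lower number of compound 2 does not restore activity once the second methyl is there. The value of compound 3 is a limit and not a number, and both steps are minimum sizes only: the limit of > 50000 nM in this assay, at which 1 of the 3 values shown sits.

As far as these compounds go, whether the loss belongs to methyl itself or to any group on this carbon stays open; a chlorine atom, an amine or a carboxylic acid there would separate the two readings. From the compounds shown here alone, the effect of fluoro with a single methyl on the core also stays open.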